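A few compounds are considered here, and "the series" means these few. Any claim that something is new, unique, unknown or untested is made for them only; others in the source may bear on it.

In a functional assay on DU-145 cells (Homo sapiens) for cytotoxicity, read by MTT assay (a lower number here means a stronger inhibitor, a higher number a weaker inhibitor), compound 2 `CC(C)=CC[C@@H](OC(=O)C1CCCO1)C1=CC(=O)c2c(O)ccc(O)c2C1=O` gives 10500 nM and compound 1 `CC(C)=CC[C@@H](OC(=O)CC(C)(O)C(C)C)C1=CC(=O)c2c(O)ccc(O)c2C1=O` gives 16900 nM, two values within the scatter of each other. Compound 3 `CCC(C)(O)CC(=O)O[C@H](CC=C(C)C)C1=CC(=O)c2c(O)ccc(O)c2C1=O` carries 2-hydroxy-2-methylbutyl in place of oxolan-2-yl on a carbonyl carbon, with 2-hydroxy-2-methylbutyl in place of oxolan-2-yl on a carbonyl carbon. Within the data shown here, the only measured step that bears on this is a 1.6-fold lower number from compound 1 to compound 2 (0.21 log units; within the scatter), which lies within the scatter and exchanges 2-hydroxy-2,3-dimethylbutyl for oxolan-2-yl at the same place. No change beyond the scatter is therefore expected in this assay, with at most a slight drift towards a higher number. The estimated step is a 1.2-fold higher number from compound 2 to compound 3 (0.09 log units; within the scatter). Compound 3 is expected at 13000 nM, within an estimated range of 6500 nM to 26000 nM.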

Compound 3, half-maximal inhibitory concentration: 16000 nM
Compound 3: middle estimate off by 1.2-fold (0.09 log units), on the low side; low and high end bracket the measured number.
By their numbers in this assay, from the lowest: compounds 2, 3 and 1 (each within the scatter of the next).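

In this assay the ring is not needed to hold the number: 2-hydroxy-2-methylbutyl in place of oxolan-2-yl on the carbonyl carbon gives a 1.5-fold higher number from compound 2 to compound 3 (0.18 log units; within the scatter) and stays within the scatter. Hydrogen in place of methyl on the saturated chain carbon gives a 1.1-fold lower number from compound 1 to compound 3 (0.02 log units; within the scatter) and shows the same tolerance within the open chains. No measurement on hand accounts for these results.
On these data alone, whether an amine, a carboxylic acid or a longer chain on this carbonyl carbon would move the number beyond the scatter remains open.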